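Aryl variation on the enone arm: estimate for compound 4

The compounds below may be only part of what the source reports. "The series", "measured", "known", "first", "only" and "open" are said of these compounds alone.

Compound 1 `Cc1ccc(/C=C/C(=O)c2ccccc2NC(=O)NS(=O)(=O)c2ccc(C)cc2)cc1` gives 15.3 ug/mL in an ADME assay on the whole organism for cytotoxicity, with Artemia salina as the target, with a stated time of 24 h; on this read-out lower numbers stand for an effect already at smaller amounts and higher numbers for an effect only at larger amounts of compound.
Compound 2 `COc1ccc(/C=C/C(=O)c2ccccc2NC(=O)NS(=O)(=O)c2ccc(C)cc2)c(OC)c1` gives 16 ug/mL in this assay.
Compound 3 `CCc1cc(/C=C/C(=O)c2ccccc2NC(=O)NS(=O)(=O)c2ccc(C)cc2)cc(OC)c1OC` gives 19.2 ug/mL in this assay.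

Compound 3 carries the highest of the three numbers, yet its separations from the others, a 1.2-fold higher number from compound 2 to compound 3 (0.08 log units; within the scatter) and a 1.3-fold higher number from compound 1 to compound 3 (0.10 log units; within the scatter), lie within the scatter, so the three compounds cannot be told apart on this assay.

Compound 4 `CCOc1cc(/C=C/C(=O)c2ccccc2NC(=O)NS(=O)(=O)c2ccc(C)cc2)ccc1O` changes only the aryl group on the enone: 3-ethoxy-4-hydroxyphenyl in place of 3-ethyl-4,5-dimethoxyphenyl on a double-bonded chain carbon bound to a double-bonded chain carbon. All three measured steps concern the same position, a 1.0-fold higher number from compound 1 to compound 2 (0.02 log units; within the scatter), a 1.3-fold higher number from compound 1 to compound 3 (0.10 log units; within the scatter) and a 1.2-fold higher number from compound 2 to compound 3 (0.08 log units; within the scatter), and none leaves the scatter. No step beyond the scatter is therefore expected for compound 4, a 1.1-fold lower number from compound 3 to compound 4 (0.05 log units; within the scatter). Compound 4 is estimated at 17 ug/mL, with a range from 9 ug/mL to 32 ug/mL.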

Compound 4, concentration for half-maximal effect: 19.2 ug/mL
The estimate for compound 4 lay 1.1-fold (0.05 log units) below the measured number; low and high end bracket the measured number.
By their numbers in this assay, from the lowest: compounds 1, 2, 3 and 4 (each within the scatter of the next).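

In this assay, 3-ethoxy-4-hydroxyphenyl, with 1 hydrogen-bond donor, replaces 3-ethyl-4,5-dimethoxyphenyl, with 0, and gives no change at the digits printed from compound 3 to compound 4 (within the scatter) at this position. The steps of a 1.2-fold higher number from compound 2 to compound 4 (0.08 log units; within the scatter) and a 1.3-fold higher number from compound 1 to compound 4 (0.10 log units; within the scatter) also stay within the scatter, so the added hydrogen-bond donor brings no readable step here. Nothing measured on these compounds offers an explanation for this flat result. Open, on these data alone, is whether an amine or a carboxylic acid on this aryl group would give a step beyond the scatter. Also open, as far as these compounds go, is whether a saturated cyclohexyl group in its place would do so.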